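The source may hold more compounds than are shown below. What is called first, only, known or untested is meant among the compounds shown, and "the series" means these compounds.

Three compounds have been measured in an assay on membranes from striatum (strain Sprague-Dawley) for displacement of a labelled ligand from sodium-dependent dopamine transporter (Rattus norvegicus), read by scintillation counting, with a stated time of 120 min; on this read-out higher numbers stand for weaker inhibition and lower numbers for stronger inhibition:

compound 1, `Fc1ccc(C(SCCNC2CCN(Cc3ccc(C(F)(F)F)cc3)CC2)c2ccc(F)cc2)cc1`, gives 190 nM
compound 2, `Fc1ccc(C(SCCNC2CCN(Cc3cc4ccccc4[nH]3)CC2)c2ccc(F)cc2)cc1`, gives 179 nM
compound 3, `O=C(c1ccccc1)N1CCC(NCC[S+]([O-])C(c2ccc(F)cc2)c2ccc(F)cc2)CC1`, gives 79.1 nM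

Among these three numbers compound 1 stands highest. Its nearest neighbour is compound 2, reached by a 1.1-fold lower number from compound 1 to compound 2 (0.03 log units; within the scatter), a step that stays within the scatter. Among the compounds with values here, the furthest is compound 3, whose number is lower than that of compound 1 by a margin beyond the scatter; compound 3, however, differs from compound 1 in more than one place, so no single step connects them.

The unmeasured compound 4, `O=C(c1ccccc1F)N1CCC(NCCSC(c2ccc(F)cc2)c2ccc(F)cc2)CC1`, is derived from compound 1 by (2-fluorophenyl)carbonyl in place of 4-(trifluoromethyl)benzyl on an amine nitrogen in a ring. Within the data shown here, only one measured step alters a group at this same amine nitrogen in a ring, namely a 1.1-fold lower number from compound 1 to compound 2 (0.03 log units; within the scatter), and it lies within the scatter. Compound 3, which also carries a carbonyl-linked phenyl on that nitrogen, gives 79.1 nM, which hints that a lower number is possible. The expected step is therefore a 1.9-fold lower number from compound 1 to compound 4 (0.28 log units; within the scatter), a moderate move toward a lower number. Compound 4 is estimated at 100 nM, with a likely range from 40 nM to 250 nM.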

Compound 4, inhibition constant: 46.1 nM
Compound 4: the middle estimate sits 2.2-fold (0.34 log units) above what was measured; the measured number falls inside the stated range.
By their numbers in this assay, from the lowest: compounds 4 and 3 (each within the scatter of the next); then compounds 2 and 1 (each within the scatter of the next).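

In this assay the amine nitrogen in a ring now proves responsive to the group it carries: (2-fluorophenyl)carbonyl in place of 4-(trifluoromethyl)benzyl gives a 4.1-fold lower number from compound 1 to compound 4 (0.62 log units; beyond the scatter) and so clearly exceeds the earlier change at this nitrogen, which stayed within the scatter. The same group in place of (1H-indol-2-yl)methyl gives a 3.9-fold lower number from compound 2 to compound 4 (0.59 log units; beyond the scatter) and shows a similar shift from a second starting point, so the result does not hang on compound 1 alone. Nothing available here speaks to the reason for this shift.

The change brings in the carbonyl and the fluorine on the phenyl ring together, so the compounds shown do not separate what each contributes. From the compounds shown here alone, how a sulfonyl link on this nitrogen, or a pyridine ring in place of the phenyl, would read in this assay also stays open.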